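A few compounds are considered here, and "the series" means these few. Any claim that something is new, unique, unknown or untested is made for them only; others in the source may bear on it.

Of the compounds shown here, two built on one shared core have so far been tested in a functional assay on MCF7 cells (Homo sapiens) for antiproliferative activity, read by MTT assay; on this read-out lower numbers stand for stronger inhibition and higher numbers for weaker inhibition. Compound 1 `Cc1cccc(Nc2nccc(-c3ccc(Cl)cc3Cl)n2)c1` gives 249000 nM in this assay, and compound 2 `O=[N+]([O-])c1ccc(Nc2nccc(-c3ccc(Cl)cc3Cl)n2)cc1` gives 192000 nM. Compound 2 thus carries the lower of the two numbers, but its gap to compound 1 lies within the usual scatter of repeated measurements, so the two cannot be told apart. Both numbers are large, which on this read-out means weak inhibition.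

Compound 3 `O=[N+]([O-])c1ccc(Nc2nccc(-c3ccc(Br)cc3)n2)cc1` has not yet been measured. It differs from compound 2 in one place: 4-bromophenyl in place of 2,4-dichlorophenyl on an aromatic carbon. The 2,4-dichlorophenyl leaves and a 4-bromophenyl enters on an aromatic carbon of a six-membered aromatic ring with 2 nitrogen. Among the measured compounds shown here, no pair of measured compounds shows what such an exchange does to the read-out, so the numbers at hand point in no direction. The expected step is therefore a 1.0-fold higher number from compound 2 to compound 3 (0.02 log units; within the scatter), a change no larger than the scatter. For compound 3 the estimated value in this assay is 200000 nM, with a range from 60000 nM to 600000 nM.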

Compound 3, half-maximal inhibitory concentration: 681000 nM
The estimate for compound 3 lay 3.4-fold (0.53 log units) below the measured number; the measured number lies above the stated range.
By their numbers in this assay, from the lowest: compounds 2 and 1 (each within the scatter of the next); then compound 3.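

The aromatic carbon next to the ring nitrogen is not indifferent to what it carries: in this assay, putting 4-bromophenyl in place of 2,4-dichlorophenyl gives a 3.5-fold higher number from compound 2 to compound 3 (0.55 log units; beyond the scatter), a modest step towards weaker inhibition. Among the compounds shown here, compounds 1 and 2 both carry 2,4-dichlorophenyl, so they could say nothing about this place, and this step is the first change here that stands clear of the scatter. The exchange alters the halogens on the ring in more than one way, since two chlorine atoms leave and one bromine enters, and no measurement at hand gives a reason for the step.

This single step cannot show whether the weaker inhibition goes with the loss of a chlorine, with the entry of bromine, or with both, and a 4-chlorophenyl or an unsubstituted phenyl at this place would help to separate these. Also open, on these data alone, is what a ring carrying an amine or a carboxylic acid would do here, and whether the step would be the same on compound 1, which has a different group at the other end of the shared core.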